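Swapping Vinyl for Iodo at the Assay Limit

The compounds below may be only part of what the source reports. "The series", "measured", "known", "first", "only" and "open" are said of these compounds alone.

Compound 1 `C=Cc1nc2ccccc2s1`: > 40000 nM
Compound 2 `CC#Cc1nc(C(=O)OCC)cs1`: > 40000 nM

In a functional assay on HCT-116 cells (Homo sapiens) for cytotoxicity, with a stated time of 3 days (on this read-out higher numbers stand for weaker inhibition and lower numbers for stronger inhibition), compound 1 gives > 40000 nM, which is a limit of the assay and not a number. Compound 2 gives > 40000 nM, and this too is a limit. The whole record so far therefore stands at one place, (the limit of > 40000 nM in this assay, at which 2 of the 2 values shown sit). Going by the values given here, neither compound has a numerical potency, and no measured step between related compounds is available to size a change on the shared core.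

The next compound is compound 3 `Ic1nc2ccccc2s1`, in which iodo takes the place of vinyl on an aromatic carbon, next to the ring nitrogen and next to the ring sulfur: iodo in place of vinyl on an aromatic carbon. The expectation rests on compound 1, with > 40000 nM, a limit and not a number. With nothing measured to suggest otherwise, no step beyond the usual scatter is expected in this assay, and a further limit would be no surprise. The estimated step is a number no higher from compound 1 to compound 3 (the limit leaves the size open). For compound 3 the expected value is 40000 nM, with an estimated range from 15000 nM to 80000 nM.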

Compound 3, half-maximal inhibitory concentration: > 40000 nM
Compound 3 ended at the assay's limit; the forecaster's own chance of this, stated with the estimate: 65%; the middle value lies on the limit itself.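

No step can be read from compound 1 to compound 3, with iodo in place of vinyl, since in this assay both results are limits and not numbers. The compounds shown leave open whether any change to these structures brings a numerical potency, and the record still stands at one place: the limit of > 40000 nM in this assay, at which 3 of the 3 values shown sit.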